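Shortening an ethoxy to a methoxy on a shared core

This account rests on a few compounds, and the source may have more. Where it says the series, first, only, none or still open, it means among the compounds named here.

Of the compounds shown here, two of one series have been tested in a functional assay on Hep 3B2 cells (Homo sapiens) for antiproliferative activity, read by MTT assay, with a stated time of 24 h, tested at 0.02 ug/mL; on this read-out higher numbers stand for a stronger effect at the one concentration tested and lower numbers for a weaker effect. Compound 1 `Cc1c(C(=O)Nc2c(F)cc(-c3cccc(F)c3)cc2F)nc2ccc(F)cc2c1C(=O)O` gives -0.13%. Compound 2 `CCOc1ccc2nc(C(=O)Nc3c(F)cc(-c4cccc(F)c4)cc3F)c(C)c(C(=O)O)c2c1` gives 0.05%. The two differ only in the group on the aromatic carbon: going a number 0.2 percentage points higher from compound 1 to compound 2 (within the scatter). Compound 2 therefore stands alongside compound 1, the pair sitting within the scatter of each other, and neither shows a detectable effect at the single concentration used.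

Compound 3 `COc1ccc2nc(C(=O)Nc3c(F)cc(-c4cccc(F)c4)cc3F)c(C)c(C(=O)O)c2c1` is not yet measured. It differs from compound 2 by hydrogen in place of methyl on a saturated chain carbon bound to an oxygen on an aromatic ring. Within the data shown here, only one measured step exists, and it touches the same region of the core, the exchange of fluoro for ethoxy from compound 1 to compound 2, which stayed within the scatter. Among the measured compounds shown here, no step concerning the ethyl-to-methyl shortening has been measured. Given that both measured compounds show essentially no inhibition, and that the one change in this region made no difference beyond the scatter, compound 3 is expected to follow suit, with a step of a number 0.1 percentage points lower from compound 2 to compound 3 (within the scatter) in this assay. The estimated value for compound 3 is 0%, with a range from -10% to 10%.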

Compound 3, a percentage reported as inhibition, at one concentration (the size of the read-out at that concentration, not a potency): -0.57%
Compound 3: the middle estimate sits 0.6 percentage points above what was measured; the range from low to high includes it.
By their numbers in this assay, from the lowest: compounds 3, 1 and 2 (each within the scatter of the next).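

Within this assay, shortening the ethoxy to a methoxy on the shared core gives a number 0.6 percentage points lower from compound 2 to compound 3 (within the scatter) and so adds a new kind of exchange at this place: the earlier pair varied the group on the aromatic carbon, while this step varies only the length of the saturated chain bound to the oxygen. Methoxy in place of fluoro gives a number 0.4 percentage points lower from compound 1 to compound 3 (within the scatter) and shows that fluoro, ethoxy and methoxy now all read alike on this carbon, each within the scatter of the others and all close to no inhibition at the one concentration tested. Nothing on hand accounts for this sameness.

Because all three values lie so near zero, these compounds cannot show whether this position matters under conditions where the core has a clear effect, and a higher concentration might separate them. From the compounds shown here alone, it also stays open whether a different group on this carbon, such as an amine or a longer chain like butoxy, would give a reading clear of the scatter in this assay at all.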